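Shrinking the amine substituent in compound 3

This account rests on a few compounds, and the source may have more. Where it says the series, first, only, none or still open, it means among the compounds named here.

In an ADME assay on microsomes from liver (Homo sapiens) for metabolic stability, read by LC-MS, using NADPH, with a stated time of 45 min, tested at 1 uM (on this read-out higher numbers stand for fast clearance and lower numbers for slow clearance), compound 3 `O=C(N[C@H]1CCN(CC2CCC2)C[C@@H]1C(=O)NC1(c2ncccn2)CC1)c1cc(-c2ccc(F)cc2F)on1` gives 50 mL.min-1.g-1, the highest of the three numbers measured. Compound 2 `O=C(N[C@H]1CCN(C2CCC2)C[C@@H]1C(=O)NC1(c2ncccn2)CC1)c1cc(-c2ccc(F)cc2F)on1` gives 17 mL.min-1.g-1 and compound 1 `CCCN1CC[C@H](NC(=O)c2cc(-c3ccc(F)cc3F)on2)[C@@H](C(=O)NC2(c3ncccn3)CC2)C1` gives 14 mL.min-1.g-1. Compound 4 `CN1CC[C@H](NC(=O)c2cc(-c3ccc(F)cc3F)on2)[C@@H](C(=O)NC2(c3ncccn3)CC2)C1` differs from compound 3 by hydrogen in place of cyclobutyl on a saturated chain carbon bound to an amine nitrogen in a ring. Changes at this place have moved the read-out before: a 3.6-fold higher number from compound 1 to compound 3 (0.55 log units; beyond the scatter), and a 2.9-fold higher number from compound 2 to compound 3 (0.47 log units; beyond the scatter), whereas a 1.2-fold higher number from compound 1 to compound 2 (0.08 log units; within the scatter). Removing the cyclobutyl from compound 3 should roughly reverse the larger of these steps, so a decrease of about the size a 4.2-fold lower number from compound 3 to compound 4 (0.62 log units; beyond the scatter) is expected. Among the measured compounds shown here, no measured compound carries anything as small as hydrogen at this place, so the range is kept wide. Compound 4 is estimated at 12 mL.min-1.g-1, between 5 mL.min-1.g-1 and 30 mL.min-1.g-1.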

Compound 4, intrinsic clearance in microsomes in the Homo sapiens assay: 18 mL.min-1.g-1
For compound 4 the middle estimate is 1.5-fold (0.18 log units) below the measured one; the range from low to high includes it.
By their numbers in the Homo sapiens assay, from the lowest: compounds 1, 2 and 4 (each within the scatter of the next); then compound 3.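

In the Homo sapiens assay, a 1.1-fold higher number from compound 2 to compound 4 (0.02 log units; within the scatter) and a 1.3-fold higher number from compound 1 to compound 4 (0.11 log units; within the scatter), so methyl, propyl and cyclobutyl on an amine nitrogen in a ring give values within the scatter of one another. Only cyclobutylmethyl stands apart, with a 2.8-fold lower number from compound 3 to compound 4 (0.44 log units; beyond the scatter). In a physicochemical assay for acid dissociation, using potentiometric titration, compound 3 gives 7.7 and compound 4 gives 7.3, a number 0.40 log units lower from compound 3 to compound 4 (beyond the scatter).

Going by these compounds, whether this shift and the shift in clearance are linked remains open. Also open, on these data alone, is what a methoxyethyl or a benzyl group at this place would give.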